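The compounds below may be only part of what the source reports. "The series", "measured", "known", "first", "only" and "open" are said of these compounds alone.

Compound 1 `COC(=O)NS(=O)(=O)c1sc(CC(C)C)cc1-c1cccc(Cn2ccnc2)c1`: 400 nM
Compound 2 `COCCOC(=O)NS(=O)(=O)c1sc(CC(C)C)cc1-c1cccc(Cn2ccnc2)c1`: 480 nM

In an assay on HEK293 cells for displacement of a labelled ligand from Type-2 angiotensin II receptor (Homo sapiens), read by scintillation counting, with a stated time of 240 min (on this read-out lower numbers stand for stronger inhibition and higher numbers for weaker inhibition), compound 1 gives 400 nM, the lowest of the two numbers, and compound 2 gives 480 nM; the step of a 1.2-fold higher number from compound 1 to compound 2 (0.08 log units; within the scatter) falls within the scatter. Compound 3 `CCCC(=O)NS(=O)(=O)c1sc(CC(C)C)cc1-c1cccc(Cn2ccnc2)c1` differs from compound 1 in one place: propyl in place of methoxy on a carbonyl carbon. For the measured compounds named here, the single measured step, a 1.2-fold higher number from compound 1 to compound 2 (0.08 log units; within the scatter), alters a different part of the chain, so no measured step covers this change. Compound 3 is therefore expected to land near compound 1, with an expected step of a 1.3-fold higher number from compound 1 to compound 3 (0.10 log units; within the scatter). The estimate for compound 3 is 500 nM, expected to fall between 200 nM and 1500 nM.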

Compound 3, inhibition constant: 300 nM
Compound 3: middle estimate off by 1.7-fold (0.22 log units), on the high side; the range from low to high includes it.
By their numbers in this assay, from the lowest: compounds 3, 1 and 2 (each within the scatter of the next).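

On the carbonyl carbon, a group attached through carbon can replace one attached through oxygen without a change beyond the scatter in this assay (a 1.3-fold lower number from compound 1 to compound 3 (0.12 log units; within the scatter)). The comparison with the longer 2-methoxyethoxy group also stays within the scatter (a 1.6-fold lower number from compound 2 to compound 3 (0.20 log units; within the scatter)), so these three groups cannot be told apart at this position. No available evidence bears on this result. As far as these compounds go, whether an amine, a phenyl ring or a longer chain such as hexyl at this carbonyl carbon would stay in the same range remains open.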